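An allyl methyl amide replaces the aminoethyl amide

The source may hold more compounds than are shown below. What is called first, only, known or untested is meant among the compounds shown, and "the series" means these compounds.

In a functional assay on PC-3 cells (Homo sapiens), read by MTT assay, with a stated time of 48 h (on this read-out higher numbers stand for weaker inhibition and lower numbers for stronger inhibition), compound 1 (`CCOC(=O)CN(C)C(=O)c1ccc(C(CC)(CC)c2ccc(OCC(O)C(C)(C)C)c(C)c2)n1CC`) carries ((ethoxycarbonyl)methyl)(methyl)amino on the carbonyl carbon and gives 25500 nM as its reading. Compound 2 (`CCn1c(C(=O)NCCN(C)C)ccc1C(CC)(CC)c1ccc(OCC(O)C(C)(C)C)c(C)c1`) gives 1630 nM with (2-(dimethylamino)ethyl)amino in that place. Compound 3 (`CCn1c(C(=O)NCCN)ccc1C(CC)(CC)c1ccc(OCC(O)C(C)(C)C)c(C)c1`) gives 940 nM with (2-aminoethyl)amino there. That reading matches the previous one within the scatter (a 1.7-fold lower number from compound 2 to compound 3 (0.24 log units; within the scatter)) and sits far under the ester amide (a 27-fold lower number from compound 1 to compound 3 (1.43 log units; beyond the scatter)). Compound 4 (`C=CCN(C)C(=O)c1ccc(C(CC)(CC)c2ccc(OCC(O)C(C)(C)C)c(C)c2)n1CC`) has allyl(methyl)amino in place of (2-aminoethyl)amino on a carbonyl carbon and has not yet been measured. Its entering group resembles that of compound 1 in being a methyl-bearing amino group with no second nitrogen, while the two lower readings both come with a second nitrogen on the chain. Among the measured compounds shown here, the large steps away from the ester amide (a 16-fold lower number from compound 1 to compound 2 (1.19 log units; beyond the scatter) and a 27-fold lower number from compound 1 to compound 3 (1.43 log units; beyond the scatter)) therefore bear most directly, although only one compound of that kind has been read and it also holds an ester. A rise beyond the scatter is expected, perhaps short of the full distance back to the ester amide (a 9.6-fold higher number from compound 3 to compound 4 (0.98 log units; beyond the scatter)). In this assay the estimate for compound 4 is 9000 nM with 2500 nM and 30000 nM as the ends of the expected range.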

Compound 4, half-maximal inhibitory concentration: 25900 nM
Estimate against measurement, compound 4: 2.9-fold (0.46 log units) below, within the range that was stated.
By their numbers in this assay, from the lowest: compounds 3 and 2 (each within the scatter of the next); then compounds 1 and 4 (each within the scatter of the next).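

Compound 4 settles a question that compound 1 alone could not, as its ester might have accounted for the high number. In this assay, vinyl in place of ethoxycarbonyl gives a 1.0-fold higher number from compound 1 to compound 4 (0.01 log units; within the scatter), which is within the scatter, so the high number at this position does not depend on the ester. Allyl(methyl)amino on the carbonyl carbon gives a 28-fold higher number from compound 3 to compound 4 (1.44 log units; beyond the scatter) when it replaces (2-aminoethyl)amino and a 16-fold higher number from compound 2 to compound 4 (1.20 log units; beyond the scatter) when it replaces (2-(dimethylamino)ethyl)amino, so among these four compounds the two low numbers belong to the amides with a second nitrogen on the chain, and no compound goes against this.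

Compounds 2 and 3 also keep the amide hydrogen, which compounds 1 and 4 lack, so the second nitrogen and the amide hydrogen cannot be told apart here. A (2-aminoethyl)(methyl)amino group would have the second nitrogen without the amide hydrogen, and a butylamino group would have the amide hydrogen without the second nitrogen, so either could separate the two. Nothing measured here explains why the numbers divide in this way.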